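This account rests on a few compounds, and the source may have more. Where it says the series, first, only, none or still open, it means among the compounds named here.

Measured compounds:
- compound 1, `COc1cc(C(=O)c2ccc3[nH]ccc3c2)cc(OC)c1OC`: 104 nM
- compound 2, `COc1cc(C(=O)c2ccc3cc[nH]c3c2)cc(OC)c1OC`: 510 nM

Of the compounds shown here, two have been measured in a functional assay on KB cells (Homo sapiens) for inhibition, with a stated time of 72 h; on this read-out lower numbers stand for stronger inhibition and higher numbers for weaker inhibition. Compound 1 gives 104 nM in this assay, which is the lowest of the two numbers. Compound 2 gives 510 nM in this assay, a higher number, and the gap between these two values lies beyond the usual scatter of repeated measurements. The two compounds share the same core, and their values show that the way the two rings of that core are joined matters for the read-out.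

Compound 3, `COc1cc(C(=O)c2ccc3c(ccn3CCN(C)C)c2)cc(OC)c1OC`, has not yet been measured. It is built from compound 1 by a single change: 2-(dimethylamino)ethyl in place of hydrogen on an aromatic nitrogen. The core, the carbonyl and the three methoxy groups are unchanged.

Going by the values given here, no pair of measured compounds shows this kind of change, so there is no measured step to lean on. The step from compound 1 to compound 3 is expected to be small, toward a slightly higher number, and likely within the scatter: a 1.4-fold higher number from compound 1 to compound 3 (0.16 log units; within the scatter). Compound 3 is therefore estimated to give about 150 nM in this assay, with a plausible range from 40 nM to 600 nM.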

Compound 3, half-maximal inhibitory concentration: 5200 nM
The estimate for compound 3 lay 35-fold (1.54 log units) below the measured number; the measured number lies above the stated range.
By their numbers in this assay, from the lowest: compound 1; then compound 2; then compound 3.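

In this assay, 2-(dimethylamino)ethyl in place of hydrogen on an aromatic nitrogen brings a 50-fold higher number from compound 1 to compound 3 (1.70 log units; beyond the scatter), and this large step lies beyond the usual scatter. The earlier compounds shown here showed only that the way the two rings of the shared core are joined matters, whereas this result shows that the aromatic nitrogen of the five-membered ring is itself a place where the read-out responds strongly: here, this chain goes with much weaker inhibition than the plain hydrogen of compound 1. Nothing measured in the data at hand speaks to the reason for this large rise in the number.

On these data alone, it remains open whether the rise is tied to losing the hydrogen on this nitrogen or to the particular chain placed there, and a methyl group on the same nitrogen would help to tell these two readings apart. As far as these compounds go, it is also open whether a shorter or longer chain, or a chain ending in a hydroxyl group or a carboxylic acid instead of the dimethylamino group, would give a similar number.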